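The source may report more compounds than this note shows. Statements on the series, on what has been measured and on what is new or still open speak of the compounds shown alone.

Measured so far in a functional assay on SK-OV-3 cells (Homo sapiens) for cytotoxicity, read by sulforhodamine B assay, with a stated time of 2 days, tested at 100 uM; a lower number here means less inhibition, a higher number more inhibition at the concentration tested (going by the name of the read-out):
- compound 1, `COc1cccc(-c2nc3c(-c4ccc(Cl)cc4)n[nH]c3c(=O)n2NC(=O)c2ccccc2)c1`: 81.7%
- compound 2, `O=C(Nn1c(-c2cccc([N+](=O)[O-])c2)nc2c(-c3ccco3)n[nH]c2c1=O)c1ccccc1`: 17.9%

Compound 2 stands lowest of the two numbers in hand. Compound 1 sits well above it, and the gap of inhibition between compound 2 and compound 1 lies beyond the scatter of this assay. For the measured compounds named here, the two compounds differ in more than one place, so no single structural step between them can be read off; the comparison only shows that the two values are far apart.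

Compound 3, `COc1cccc(-c2nc3c(-c4ccco4)n[nH]c3c(=O)n2NC(=O)c2ccccc2)c1`, has not been measured. It is compound 2 with one change: methoxy in place of nitro on an aromatic carbon. Nothing else moves, so compound 3 shares the methoxy-bearing ring with compound 1 and the rest of its structure with compound 2.

Going by the values given here, an upward step from compound 2 to compound 3 is expected in this assay, beyond the scatter but with wide uncertainty, since only one compound with methoxy in that place is known and it differs from compound 3 elsewhere. Compound 3 is estimated at 50%, range 20% to 85%, because compound 1 gives 81.7% with the same methoxy group in place while compound 2 with nitro gives 17.9%. The expected step is a number 32.1 percentage points higher from compound 2 to compound 3 (beyond the scatter).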

Compound 3, a percentage reported as inhibition, at one concentration (the size of the read-out at that concentration, not a potency): 35.2%
Estimate against measurement, compound 3: 14.8 percentage points above; the measured number falls inside the stated range.
By their numbers in this assay, from the lowest: compound 2; then compound 3; then compound 1.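

In this assay, methoxy in place of nitro on an aromatic carbon gives a number 17.3 percentage points higher from compound 2 to compound 3 (beyond the scatter) with furan-2-yl held constant, so this position affects the read-out, though the step is modest. With methoxy held constant, furan-2-yl in place of 4-chlorophenyl gives a number 46.5 percentage points lower from compound 1 to compound 3 (beyond the scatter) in the same assay, so the second position also matters, and its step is the larger of the two. The data at hand offer no explanation for either step.

The compounds shown carry the change from 3-nitrophenyl to 3-methoxyphenyl only with furan-2-yl, so its size with 4-chlorophenyl at the other position remains open. Also open, going by these compounds, is how an amine or a carboxylic acid would read in place of methoxy on that aromatic carbon, and whether a methyl or a longer chain in place of furan-2-yl would fall nearer compound 1 or compound 3.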